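This account rests on a few compounds, and the source may have more. Where it says the series, first, only, none or still open, it means among the compounds named here.

Notes on the series: in a functional assay on U-937 cells (Homo sapiens) for inhibition, read by sulforhodamine B assay, with a stated time of 72 h (on this read-out lower numbers stand for stronger inhibition of growth and higher numbers for weaker inhibition of growth), compound 1 (`COc1ccc2c(ccn2N2C[C@H]3CN(c4ncc(C(=O)NO)cn4)C[C@H]3C2)c1`) gives 390 nM and compound 2 (`O=C(NO)c1cnc(N2C[C@H]3CN(Cc4cc(Cl)cc(Cl)c4)C[C@H]3C2)nc1`) gives 300 nM. These two values lie within the scatter of each other, so compound 2 cannot be separated from compound 1 on this read-out. Among the measured compounds shown here, the two compounds differ in more than one place, and no single-change step has been measured yet.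

Compound 3 (`COc1ccc(CN2C[C@@H]3CN(c4ncc(C(=O)NO)cn4)C[C@@H]3C2)cc1`) is still to be measured in this assay. Relative to compound 2 it shows (4-methoxyphenyl in place of 3,5-dichlorophenyl on a saturated chain carbon bound to an amine nitrogen in a ring), that is, 4-methoxyphenyl in place of 3,5-dichlorophenyl on a saturated chain carbon bound to an amine nitrogen in a ring.

For the measured compounds named here, with no measured step to lean on, no change beyond the scatter is expected, and the expected step is a 1.2-fold higher number from compound 2 to compound 3 (0.07 log units; within the scatter). For compound 3 the estimated value is 350 nM, with an expected range of 120 nM to 1000 nM.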

Compound 3, concentration for 50% growth inhibition: 550 nM
For compound 3 the middle estimate is 1.6-fold (0.20 log units) below the measured one; low and high end bracket the measured number.
By their numbers in this assay, from the lowest: compounds 2, 1 and 3 (each within the scatter of the next).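

In this assay, among the compounds shown here, the first single-change step at this place, on a saturated chain carbon bound to an amine nitrogen in a ring, is a 1.8-fold higher number from compound 2 to compound 3 (0.26 log units; within the scatter) for 4-methoxyphenyl in place of 3,5-dichlorophenyl. This exchange removes both chlorine atoms and brings in one oxygen and one hydrogen-bond acceptor, yet it cannot be separated from no change on this read-out. No measured evidence on the two groups is available to account for this result.

On these data alone, whether an amine or a carboxylic acid on the phenyl ring would give a step beyond the scatter remains open. As far as these compounds go, it is also open whether a longer chain in place of the saturated chain carbon would give such a step.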